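Methyl for Methoxy on a Shared Core: One Step Ahead

The source may report more compounds than this note shows. Statements on the series, on what has been measured and on what is new or still open speak of the compounds shown alone.

The measured compounds:
compound 1 `C=CCNC(=S)N/N=C\c1ccnc2ccccc12` gives 970 nM
compound 2 `S=C(N/N=C\c1ccnc2ccccc12)Nc1ccc(Br)cc1` gives 990 nM
compound 3 `COc1ccc(NC(=S)N/N=C\c2ccnc3ccccc23)cc1` gives 990 nM

In a functional assay on MCF7 cells (Homo sapiens) for cytotoxicity, read by MTT assay, with a stated time of 48 h (a higher number here means a weaker inhibitor, a lower number a stronger inhibitor), compound 3 stands level with compound 2 at the digits shown and within the scatter of compound 1, so none of the three can be ordered. Compound 4 `Cc1ccc(NC(=S)N/N=C\c2ccnc3ccccc23)cc1` differs from compound 3 by methyl in place of methoxy on an aromatic carbon. Within the data shown here, the only measured step that also exchanged a group on an aromatic carbon, no change at the digits printed from compound 2 to compound 3 (within the scatter), stayed flat, as did a 1.0-fold higher number from compound 1 to compound 2 (0.01 log units; within the scatter) and a 1.0-fold higher number from compound 1 to compound 3 (0.01 log units; within the scatter). Nothing among these changes has moved the number, so for compound 4 a step no larger than the scatter is expected, no change at the digits printed from compound 3 to compound 4 (within the scatter). Compound 4 is therefore estimated at 990 nM, with a range from 500 nM to 2000 nM.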

Compound 4, half-maximal inhibitory concentration: 980 nM
Estimate against measurement, compound 4: 1.0-fold (0.00 log units) above; low and high end bracket the measured number.
By their numbers in this assay, from the lowest: compounds 1, 4, 2 and 3 (each within the scatter of the next).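

In this assay the aromatic carbon para to a large group now carries methyl as well as methoxy and bromo, with a 1.0-fold lower number from compound 3 to compound 4 (0.00 log units; within the scatter) and a 1.0-fold lower number from compound 2 to compound 4 (0.00 log units; within the scatter) as the two exchanges. Losing the hydrogen-bond acceptor of the methoxy leaves the number within the scatter. The 4-methylphenyl group also matches allyl on the amide-type nitrogen, with a 1.0-fold higher number from compound 1 to compound 4 (0.00 log units; within the scatter) as that step. No measurement offered here explains this flatness.

As far as these compounds go, whether an amine or a carboxylic acid on this aromatic carbon would move the number remains open. So does whether a longer chain on the amide-type nitrogen would.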